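The compounds below may be only part of what the source reports. "The series", "measured", "known", "first", "only" and "open" are said of these compounds alone.

Measured so far:
Compound 1, `CN(C)c1ccc(-c2nc3c(N4CCN(Cc5ccncc5)CC4)c(Br)cnc3[nH]2)cc1`: 700 nM
Compound 2, `Cc1cc(CN2CCN(c3c(Br)cnc4[nH]c(N5CCN(Cn6cccn6)CC5)nc34)CC2)no1`: 120 nM

Both compounds were tested in a functional assay on HCT-116 cells (Homo sapiens) for inhibition, read by MTT assay, with a stated time of 72 h; on this read-out higher numbers stand for weaker inhibition of growth and lower numbers for stronger inhibition of growth. Compound 1 gives 700 nM, the higher of the two numbers, so of this pair it is the one with the weaker growth inhibition. Compound 2 gives 120 nM, a lower number, and the gap between the two lies beyond the usual scatter of repeated measurements. These two compounds differ in several places at once. Within the data shown here, no single structural step between them can be drawn.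

Compound 3, `CC(c1ccncc1)N1CCN(c2c(Br)cnc3[nH]c(-c4ccc(N(C)C)cc4)nc23)CC1`, has not yet been measured in this assay. It is built from compound 1 by one small change: methyl in place of hydrogen on a saturated chain carbon bound to an amine nitrogen in a ring and an aromatic carbon. Among the measured compounds shown here, no measured pair shows this same change, so there is no earlier step to lean on. A change this small, adding a single carbon on a saturated chain carbon bound to an amine nitrogen in a ring and an aromatic carbon, is expected to move the number only a little, and the step of a 1.2-fold lower number from compound 1 to compound 3 (0.07 log units; within the scatter) is expected to stay within the scatter. Compound 3 is therefore estimated at 600 nM, with a range from 250 nM to 1500 nM.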

Compound 3, concentration for 50% growth inhibition: 900 nM
For compound 3 the middle estimate is 1.5-fold (0.18 log units) below the measured one, within the range that was stated.
By their numbers in this assay, from the lowest: compound 2; then compounds 1 and 3 (each within the scatter of the next).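

In this assay, among these compounds, this is the first comparison of two compounds that differ in one place only: exchanging (pyridin-4-yl)methyl for 1-(pyridin-4-yl)ethyl gives a 1.3-fold higher number from compound 1 to compound 3 (0.11 log units; within the scatter). On this read-out the two compounds cannot be told apart, so a methyl in place of hydrogen on this saturated chain carbon, bound to an amine nitrogen in a ring and an aromatic carbon, leaves no readable mark on growth inhibition in this single pair. Nothing measured here offers an explanation for this result.

As far as these compounds go, whether a larger group such as ethyl, or a hydroxyl group, on the same carbon would also leave the number within the usual scatter remains open, since one methyl says little about how much room there is for anything bigger or different. Also open, from the compounds shown here alone, is whether the same methyl would give a similarly small step on a chain carbon of compound 2, which stands at 120 nM and carries different groups elsewhere on the shared core.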